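Aryl replacement on compound 1

The source may report more compounds than this note shows. Statements on the series, on what has been measured and on what is new or still open speak of the compounds shown alone.

In a functional assay for inhibition, with Rattus norvegicus as the target (a lower number here means a stronger inhibitor, a higher number a weaker inhibitor), compound 1 `CC(/N=c1\c(O)c(O)\c1=N/c1cccnc1)C(C)(C)C` gives 1950 nM, compound 2 `C[C@@H](/N=c1\c(O)c(O)\c1=N/c1cccnc1)C(C)(C)C` gives 1900 nM and compound 3 `CC(C)(C)/N=c1\c(O)c(O)\c1=N/c1cccnc1` gives 2800 nM, so compound 1 stands within the scatter of both neighbours. Compound 4 `CC(/N=c1\c(O)c(O)\c1=N/c1ccc(Br)cc1)C(C)(C)C` carries the change 4-bromophenyl in place of pyridin-3-yl on a double-bonded nitrogen. The measured steps, a 1.0-fold lower number from compound 1 to compound 2 (0.01 log units; within the scatter) and a 1.4-fold higher number from compound 1 to compound 3 (0.16 log units; within the scatter), both stay within the scatter, but neither alters the pyridin-3-yl group, so they give no direct guide to its replacement. The expected step is a 2.0-fold lower number from compound 1 to compound 4 (0.29 log units; within the scatter) in this assay, a tentative estimate whose direction the data do not fix. For compound 4 the estimated value is 1000 nM, with an expected range of 150 nM to 6000 nM.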

Compound 4, half-maximal inhibitory concentration: 1260 nM
Compound 4: the middle estimate sits 1.3-fold (0.10 log units) below what was measured; low and high end bracket the measured number.
By their numbers in this assay, from the lowest: compounds 4, 2, 1 and 3 (each within the scatter of the next, the first and the last beyond it).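

In this assay, 4-bromophenyl in place of pyridin-3-yl on a double-bonded nitrogen gives a 1.5-fold lower number from compound 1 to compound 4 (0.19 log units; within the scatter) for this first change at the aryl group. The place therefore accepts an all-carbon ring carrying bromine without a step beyond the scatter, so the ring nitrogen of pyridin-3-yl is not needed for a number in this range. Nothing measured here bears on the reason for this step.

Plain phenyl would separate the loss of the ring nitrogen from the entry of bromine. Going by these compounds, it remains open whether an amine or a carboxylic acid on the ring would move the number beyond the scatter.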